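Benzylsulfonyl in place of vinylcarbonyl on the shared core

The source may report more compounds than this note shows. Statements on the series, on what has been measured and on what is new or still open speak of the compounds shown alone.

compound 1 `COc1ccc(/C=C/C(=O)c2ccc(OC)c3c2OC(C)(C)C=C3)cc1OCC=C(C)C` gives > 10000 nM (a limit of the assay)
compound 2 `CCCCC(=O)Oc1cc(/C=C/C(=O)c2ccc(OC)c3c2OC(C)(C)C=C3)ccc1OC` gives 240 nM
compound 3 `C=CC(=O)Oc1cc(/C=C/C(=O)c2ccc(OC)c3c2OC(C)(C)C=C3)ccc1OC` gives 300 nM

In a functional assay on K562 cells (Homo sapiens) for cytotoxicity, read by MTT assay (on this read-out higher numbers stand for weaker inhibition and lower numbers for stronger inhibition), compound 3 gives 300 nM and has one close neighbour on the numbers (a 1.3-fold higher number from compound 2 to compound 3 (0.10 log units; within the scatter)). Compound 4 `COc1ccc(/C=C/C(=O)c2ccc(OC)c3c2OC(C)(C)C=C3)cc1OS(=O)(=O)Cc1ccccc1` carries benzylsulfonyl in place of vinylcarbonyl on an oxygen on an aromatic ring. The step on the carbonyl carbon stayed small, whereas a far larger one came when vinylcarbonyl replaced 3-methylbut-2-en-1-yl on that oxygen (an at least 33-fold lower number from compound 1 to compound 3 (1.52 log units; beyond the scatter)). Within the data shown here, no measured compound carries a sulfonyl group, so the guide is loose, and a moderate step toward weaker inhibition is expected (a 2.7-fold higher number from compound 3 to compound 4 (0.43 log units; beyond the scatter)). For compound 4 the estimated value is 800 nM (expected range 150 nM to 5000 nM).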

Compound 4, half-maximal inhibitory concentration: > 10000 nM
Compound 4: only a limit was reported; the forecaster's own chance of this, stated with the estimate: 12%; middle value at least 12-fold (1.09 log units) away from the limit.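

In this assay, benzylsulfonyl on an oxygen on an aromatic ring gives an at least 33-fold higher number from compound 3 to compound 4 (1.52 log units; beyond the scatter), and in place of butylcarbonyl it gives an at least 41-fold higher number from compound 2 to compound 4 (1.61 log units; beyond the scatter). Among the compounds shown, only the two carbonyl groups on this oxygen give a value inside the assay's range, while 3-methylbut-2-en-1-yl and benzylsulfonyl do not. The step between compound 1 and compound 4 cannot be read, because both values are limits: the limit of > 10000 nM in this assay, at which 2 of the 4 values shown sit.

The compounds shown do not separate the sulfonyl from its benzyl, which a methylsulfonyl group could do. On these data alone, how a carbamate on this oxygen would read also stays open.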